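A few compounds are considered here, and "the series" means these few. Any claim that something is new, unique, unknown or untested is made for them only; others in the source may bear on it.

In a functional assay on A549 cells (Homo sapiens) for antiproliferative activity, read by MTT assay, with a stated time of 48 h (a lower number here means a stronger inhibitor, a higher number a weaker inhibitor), two compounds with a shared core have been measured so far. Compound 1 `Cc1ccc(C(=O)/C=C/c2cc(Cl)cc(Cl)c2Oc2c([N+](=O)[O-])cc(C(F)(F)F)cc2[N+](=O)[O-])cc1` gives 10.1 ug/mL, and compound 2 `Cc1ccc(C(=O)/C=C/c2cccc(Cl)c2Oc2c([N+](=O)[O-])cc(C(F)(F)F)cc2[N+](=O)[O-])cc1` gives 0.95 ug/mL, the lower of the two numbers, which makes compound 2 the stronger inhibitor of this pair. The next structure is compound 3 `O=C(/C=C/c1cccc(Cl)c1Oc1c([N+](=O)[O-])cc(C(F)(F)F)cc1[N+](=O)[O-])c1ccc(Br)cc1`, and the change from compound 2 is bromo in place of methyl on an aromatic carbon. Put another way, the 4-methylphenyl of compound 2 becomes 4-bromophenyl in compound 3.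

Going by the values given here, the only measured step, an 11-fold lower number from compound 1 to compound 2 (1.03 log units; beyond the scatter), is large and beyond the scatter, but it is hydrogen in place of chloro at a different place in the molecule. It therefore gives no direct guide to swapping methyl for bromo, though it does show that one small swap can move the number a long way, so a wide range is sensible. Starting from compound 2 at 0.95 ug/mL, with no measured guide to direction, no change beyond the scatter is expected in this assay. The expected step, a 1.3-fold higher number from compound 2 to compound 3 (0.10 log units; within the scatter), is an estimate and a small one. For compound 3 the estimated value is 1.2 ug/mL, with an expected range from 0.4 ug/mL to 3.6 ug/mL.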

Compound 3, half-maximal inhibitory concentration: 10.9 ug/mL
Compound 3: middle estimate off by 9.1-fold (0.96 log units), on the low side; the measured number lies above the stated range.
By their numbers in this assay, from the lowest: compound 2; then compounds 1 and 3 (each within the scatter of the next).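

In this assay, the step of an 11-fold higher number from compound 2 to compound 3 (1.06 log units; beyond the scatter) shows that the 4-methylphenyl end of the molecule is sensitive: one heavy atom is exchanged for another, with no ring, hydrogen-bond donor, hydrogen-bond acceptor or net charge entering or leaving, yet the number moves well beyond the scatter. The earlier step, an 11-fold lower number from compound 1 to compound 2 (1.03 log units; beyond the scatter), came from a chloro at a different place, so the number is now seen to respond strongly to small swaps at two separate places, and at this position methyl gives a much stronger inhibitor than bromo. Nothing at hand explains why bromo and methyl differ so much here.

With only methyl and bromo shown at this position, it remains open whether the lower number belongs to methyl alone or would also be reached with hydrogen, fluoro, a methoxy group or an amine in the same place. Also open, going by these compounds, is whether the swap from 4-methylphenyl to 4-bromophenyl would have an effect of similar size on the core of compound 1, which carries the additional chloro.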